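The source may hold more compounds than are shown below. What is called first, only, known or untested is meant among the compounds shown, and "the series" means these compounds.

Measured so far in an ADME assay on the whole organism (Rattus norvegicus, strain Sprague-Dawley) for pharmacokinetics, using cassette dosing, at a dose of 1 mg/kg by the oral route; on this read-out lower numbers stand for lower oral bioavailability and higher numbers for higher oral bioavailability:

- compound 1 `O=C(Nc1ccc2[nH]c(=O)oc2c1)C(=O)N1CCN(c2ccc(Cl)cc2)CC1`: 17.8%
- compound 2 `O=C(Nc1ccc2[nH]c(=O)oc2c1)C(=O)N1CCN(c2ccc(F)c(F)c2)CC1`: 13%
- compound 3 `C[C@@H]1CN(c2ccc(Cl)cc2)CCN1C(=O)C(=O)Nc1ccc2[nH]c(=O)oc2c1`: 130%

Of these three numbers, the highest belongs to compound 3, and it lies beyond the scatter from both of the others. Methyl in place of hydrogen on a saturated ring carbon accompanies a number 112.2 percentage points higher from compound 1 to compound 3 (beyond the scatter). Compound 4 `C[C@@H]1CN(c2ccc(F)c(F)c2)CCN1C(=O)C(=O)Nc1ccc2[nH]c(=O)oc2c1` keeps that methyl group and differs in one place: 3,4-difluorophenyl in place of 4-chlorophenyl on an amine nitrogen in a ring.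

This exchange has been measured once, in the pair without the methyl group, where it gave a number 4.8 percentage points lower from compound 1 to compound 2 (within the scatter). On that single pair, no step beyond the scatter is expected in this assay. The data do not show whether the exchange behaves alike when the methyl group is present, so the range is kept wide. The expected change is a number 10 percentage points lower from compound 3 to compound 4 (within the scatter). For compound 4 the estimate is 120%, with an expected range from 80% to 150%.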

Compound 4, oral bioavailability: 118%
The estimate for compound 4 lay 2 percentage points above the measured number, and the stated range covers the measured number.
By their numbers in this assay, from the lowest: compounds 2 and 1 (each within the scatter of the next); then compound 4; then compound 3.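

In this assay, the exchange of 4-chlorophenyl for 3,4-difluorophenyl now has a reading with the methyl group present, a number 12 percentage points lower from compound 3 to compound 4 (beyond the scatter), and this step lies beyond the scatter, whereas the earlier one did not, yet the two steps do not differ from each other beyond their scatter: the same change on two cores in this assay, a number 4.8 percentage points lower (within the scatter) from compound 1 to compound 2 and a number 12 percentage points lower (beyond the scatter) from compound 3 to compound 4, 7.2 percentage points apart, within the scatter of two such steps. Among these compounds, the methyl group on the saturated ring carbon, earlier seen only with 4-chlorophenyl, now also accompanies a number 105 percentage points higher from compound 2 to compound 4 (beyond the scatter) with 3,4-difluorophenyl. The large rise thus holds with both groups on the amine nitrogen: the same change on two cores in this assay, a number 112.2 percentage points higher (beyond the scatter) from compound 1 to compound 3 and a number 105 percentage points higher (beyond the scatter) from compound 2 to compound 4, 7.2 percentage points apart, within the scatter of two such steps.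

Only a methyl group on that ring carbon is shown, in one stereochemical form, so it remains open whether its mirror-image form, an ethyl group or a hydroxymethyl group would accompany a similar rise. Also open, from the compounds shown here alone, is how a pyridine ring on the amine nitrogen would behave.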